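Hydroxyphenyl Swap on the Shared Pyridine Core

The compounds below may be only part of what the source reports. "The series", "measured", "known", "first", "only" and "open" are said of these compounds alone.

Among the measured compounds shown here, compound 2 `Oc1cccc(-c2cc(-c3cccnc3)cc(-c3ccccc3O)n2)c1` is the one member with a numerical reading in a functional assay on T47D cells (Homo sapiens) for cytotoxicity, read by CCK-8 assay; a lower number here means a stronger inhibitor, a higher number a weaker inhibitor; in this assay compound 2 gives 6230 nM. Compound 1 `Oc1ccc(-c2cc(-c3ccccn3)cc(-c3ccccc3O)n2)cc1` reaches only a limit in this assay, > 50000 nM, which is a limit and not a number (the limit of > 50000 nM in this assay, at which 1 of the 2 values shown sits). Compound 3 `Oc1ccc(-c2cc(-c3cccnc3)cc(-c3ccccc3O)n2)cc1` is not yet measured and differs from compound 2 by 4-hydroxyphenyl in place of 3-hydroxyphenyl on an aromatic carbon. No measured pair differs in that way alone, so the size of this step cannot be read from the numbers shown. Compound 1 also carries a 4-hydroxyphenyl group, together with a pyridin-2-yl group where compound 2 and compound 3 carry pyridin-3-yl, and compound 1 sits at the limit while compound 2 gives a number. The expected step is a 2.9-fold higher number from compound 2 to compound 3 (0.46 log units; beyond the scatter), a loss of potency beyond the usual scatter. Compound 3 is accordingly estimated at 18000 nM, within 5000 nM to 60000 nM, with a real chance that this assay again reports a limit.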

Compound 3, half-maximal inhibitory concentration: > 50000 nM
Compound 3 gave a limit, no number (the forecaster's own chance of this, stated with the estimate: 35%); middle value at least 2.7-fold (0.44 log units) away from the limit.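

With pyridin-3-yl held constant, 4-hydroxyphenyl in place of 3-hydroxyphenyl gives an at least 8.0-fold higher number from compound 2 to compound 3 (0.90 log units; beyond the scatter) in this assay as a single change at this position. Compound 1 carried this swap together with pyridin-2-yl and could not separate the two, whereas compound 3 ties a loss beyond the scatter to the hydroxyphenyl swap alone. The reading of compound 3 is a limit and not a number: the limit of > 50000 nM in this assay, at which 2 of the 3 values shown sit.

From the compounds shown here alone, the step between compound 1 and compound 3 cannot be read, so the effect of pyridin-3-yl against pyridin-2-yl stays open, as does the full size of the hydroxyphenyl step. Also open, going by these compounds, is whether a methoxy group or an amine in place of the hydroxyl of 3-hydroxyphenyl would still give a numerical reading.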